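Hydroxyphenyl isomers, all at the cytotoxicity limit

A few compounds are considered here, and "the series" means these few. Any claim that something is new, unique, unknown or untested is made for them only; others in the source may bear on it.

The shared core carries three hydroxyphenyl groups. In a functional assay on HCT-15 cells (Homo sapiens) for cytotoxicity, read by CCK-8 assay, with a stated time of 4 days (on this read-out lower numbers stand for stronger inhibition and higher numbers for weaker inhibition), compound 1 `Oc1ccc(-c2cc(-c3ccc(O)cc3)nc(-c3ccccc3O)c2)cc1` gives > 50000 nM, which is a limit of the assay. Compound 2 `Oc1ccc(-c2cc(-c3ccccc3O)nc(-c3ccccc3O)c2)cc1` gives > 50000 nM, again a limit. Compound 3 `Oc1ccc(-c2cc(-c3cccc(O)c3)cc(-c3ccc(O)cc3)n2)cc1` gives > 50000 nM, also a limit. Among the compounds with values here, the single change inside the measured set, a step that the two limits leave unreadable from compound 1 to compound 2, has no readable size; what is seen is the limit of > 50000 nM in this assay, at which 3 of the 3 values shown sit. Compound 2 therefore stands at that limit together with the other two values shown. Compound 4 `Oc1cccc(-c2cc(-c3ccccc3O)nc(-c3ccccc3O)c2)c1` differs from compound 2 by 3-hydroxyphenyl in place of 4-hydroxyphenyl on an aromatic carbon. Within the data shown here, no measured step bears on this change in readable form, and every value so far sits at the limit. Compound 4 is expected to remain there, an estimated step that the limit leaves unreadable from compound 2 to compound 4. The estimate for compound 4 is 80000 nM, between 40000 nM and 200000 nM.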

Compound 4, half-maximal inhibitory concentration: 5020 nM
Beside the measured number, compound 4's estimate is 16-fold (1.20 log units) above it; measured number below the stated range.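

In this assay, 3-hydroxyphenyl in place of 4-hydroxyphenyl, opposite the ring nitrogen, gives an at least 9.9-fold lower number from compound 2 to compound 4 (0.99 log units; beyond the scatter). Within the data shown here, this is the first readable step, and it shows that, with both 2-hydroxyphenyl groups kept, the number responds to where the hydroxyl sits on this phenyl group. The earlier compounds could not show this, and the remaining values still give no size: the limit of > 50000 nM in this assay, at which 3 of the 4 values shown sit.

Whether the hydroxyl itself matters at this position stays open, since the compounds shown include no 3-methoxyphenyl or 3-aminophenyl group there. Also open, from the compounds shown here alone, is whether the step persists when the 2-hydroxyphenyl groups are changed.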